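Aromatic heteroaryl versus carbamate on the piperidine nitrogen

The compounds below may be only part of what the source reports. "The series", "measured", "known", "first", "only" and "open" are said of these compounds alone.

Of the compounds shown here, three with the same aryl-amine arm have been measured in a functional assay on CHO-K1 cells for agonist activity at Glucose-dependent insulinotropic receptor (Homo sapiens), read by HTRF and cAMP accumulation, with a stated time of 30 min; a lower number here means a smaller maximal response, a higher number a larger maximal response. Compound 1 `CCc1cnc(N2CCC(CCCNc3ccc4c(c3)C(=O)CC4)CC2)nc1` gives 113% in this assay. Compound 2 `CC(C)(C)OC(=O)N1CCC(CCCNc2ccc3c(c2)C(=O)CC3)CC1` gives 98%, and compound 3 `CC(C)c1nc(N2CCC(CCCNc3ccc4c(c3)OCC4=O)CC2)no1`, which differs in both its core and the group on the ring nitrogen, gives 91%. Compound 2 thus stands second of the three: its gap to compound 3 lies within the scatter, while its gap to compound 1 lies beyond it. Among the compounds with values here, the one single-point step known is a number 15 percentage points lower from compound 1 to compound 2 (beyond the scatter), a modest loss when tert-butoxycarbonyl replaces 5-ethylpyrimidin-2-yl on the amine nitrogen in the ring.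

Compound 4 `CC(C)c1noc(N2CCC(CCCNc3ccc4c(c3)C(=O)CC4)CC2)n1` is the next case. It differs from compound 2 by 3-isopropyl-1,2,4-oxadiazol-5-yl in place of tert-butoxycarbonyl on an amine nitrogen in a ring, that is, an aromatic heteroaryl again takes the place of the carbamate on the same nitrogen. Within the data shown here, the only step that bears on this is the one from compound 1 to compound 2, run in the opposite sense; it suggests that putting an aromatic ring back on that nitrogen should recover a modest amount of maximal response. Compound 4 is therefore expected to show a number 7 percentage points higher from compound 2 to compound 4 (within the scatter) in this assay, giving an estimated 105% with a range from 92% to 120%.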

Compound 4, largest response reached (Emax), in percent of the reference or control that the assay uses: 110%
Estimate against measurement, compound 4: 5 percentage points below; measured number inside the range.
By their numbers in this assay, from the lowest: compounds 3 and 2 (each within the scatter of the next); then compounds 4 and 1 (each within the scatter of the next).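

In this assay, the step of a number 12 percentage points higher from compound 2 to compound 4 (beyond the scatter) shows that the higher maximal response seen with an aromatic ring on this amine nitrogen in a ring is not confined to 5-ethylpyrimidin-2-yl, as 3-isopropyl-1,2,4-oxadiazol-5-yl also stands clearly above tert-butoxycarbonyl on the same core. The two aromatic groups cannot be told apart, with a number 3 percentage points lower from compound 1 to compound 4 (within the scatter), so among these three compounds on that core it is the carbamate of compound 2 that stands apart. No measured evidence is available to explain this difference between the carbamate and the aromatic groups.

From the compounds shown here alone, it remains open whether a phenyl ring or an acetyl group on this nitrogen would side with the two aromatic heterocycles or with the carbamate. Going by these compounds, it is also open whether the pattern extends to another core: compound 3, with an aromatic ring on that nitrogen, gives 91% and seems at first sight to go against it, but it differs from compound 4 in more than one place and cannot settle the question.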